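Aryl Swap on the Shared Core: Expecting Little Movement

The compounds below may be only part of what the source reports. "The series", "measured", "known", "first", "only" and "open" are said of these compounds alone.

Of the compounds shown here, three built on the shared core have been measured in a functional assay on PC-3 cells (Homo sapiens) for cytotoxicity, read by MTT assay, with a stated time of 72 h; on this read-out lower numbers stand for stronger inhibition and higher numbers for weaker inhibition. Compound 1 `FC(F)(F)c1ccc(CSc2nc(Nc3ccccc3)c3ccccc3n2)cc1` gives 20000 nM, compound 2 `FC(F)(F)c1ccc(CSc2nc(Nc3ccccc3Cl)c3ccccc3n2)cc1` gives 20400 nM, and compound 3 `O=[N+]([O-])c1cccc(Nc2nc(SCc3ccc(C(F)(F)F)cc3)nc3ccccc23)c1` gives 13500 nM. Compound 3 holds the lowest of the three numbers, but its steps to the others, a 1.5-fold lower number from compound 1 to compound 3 (0.17 log units; within the scatter) and a 1.5-fold lower number from compound 2 to compound 3 (0.18 log units; within the scatter), both sit within the scatter, as does a 1.0-fold higher number from compound 1 to compound 2 (0.01 log units; within the scatter), so the three are not separable on this evidence.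

Compound 4 `COc1ccc(Nc2nc(SCc3ccc(C(F)(F)F)cc3)nc3ccccc23)cc1OC` is not yet measured. It differs from compound 3 as follows: 3,4-dimethoxyphenyl in place of 3-nitrophenyl on a nitrogen on an aromatic ring. The step that bears most directly on this change is the aryl exchange a 1.5-fold lower number from compound 2 to compound 3 (0.18 log units; within the scatter), and the substituent changes a 1.0-fold higher number from compound 1 to compound 2 (0.01 log units; within the scatter) and a 1.5-fold lower number from compound 1 to compound 3 (0.17 log units; within the scatter) point the same way: none of them moved this assay beyond the scatter. He therefore expects no step beyond the scatter, a 1.3-fold higher number from compound 3 to compound 4 (0.10 log units; within the scatter), in this assay. His estimate for compound 4 in this assay is 17000 nM, with a range from 8000 nM to 40000 nM.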

Compound 4, half-maximal inhibitory concentration: 14100 nM
Compound 4: middle estimate off by 1.2-fold (0.08 log units), on the high side; measured number inside the range.
By their numbers in this assay, from the lowest: compounds 3, 4, 1 and 2 (each within the scatter of the next).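

In this assay, putting 3,4-dimethoxyphenyl in place of 3-nitrophenyl on a nitrogen on an aromatic ring gives a 1.0-fold higher number from compound 3 to compound 4 (0.02 log units; within the scatter), so this exchange of a nitro group for methoxy groups on the aryl ring does not move the read-out beyond the scatter. The comparisons with the other two aryl groups read the same way, with a 1.4-fold lower number from compound 2 to compound 4 (0.16 log units; within the scatter) and a 1.4-fold lower number from compound 1 to compound 4 (0.15 log units; within the scatter), so phenyl, 2-chlorophenyl, 3-nitrophenyl and 3,4-dimethoxyphenyl cannot be told apart at this position. Nothing available speaks to why the numbers stay this close.

From the compounds shown here alone, what remains open is whether an amine or a carboxylic acid on this aryl ring would give a step beyond the scatter. Going by these compounds, it is also open whether a cyclohexyl group or a longer alkyl chain in place of the aryl ring on that nitrogen would do so.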